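The source may hold more compounds than are shown below. What is called first, only, known or untested is meant among the compounds shown, and "the series" means these compounds.

Measured in an ADME assay on cells (Erythrocyte, Homo sapiens) for activation, read by hemolysis, with a stated time of 30 min, tested at 1.25 mM; on this read-out higher numbers stand for a stronger effect at the one concentration tested and lower numbers for a weaker effect:

Compound 1 `N=C(N)c1ccc(-c2ccc(-c3cncc4ccccc34)s2)s1` – "non-toxic" (no number reported)
Compound 2 `N=C(N)c1ccc(-c2ccc(-c3ccc(Cl)cc3)o2)o1` – 14%
Compound 3 `N=C(N)c1ccc(-c2ccc(-c3ccc(F)cc3)s2)s1` – "non-toxic" (no number reported)

Three compounds that share a bent three-ring arrangement capped by an amidine have been run in this assay, but only compound 2 comes with a number: in this assay compound 2 gives 14%, while compound 1 and compound 3 are reported only as "non-toxic" without a figure. Compound 2 is therefore the single fixed point, and whether it sits higher or lower than the other two cannot be told from what is shown.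

The next compound, compound 4 `N=C(N)c1ccc(-c2ccc(-c3ccccc3)o2)o1`, is compound 2 with one small change: hydrogen in place of chloro on an aromatic carbon

Within the data shown here, no step between two measured compounds is available to show what removing such a group does in this assay. Since the change is a single heavy atom and the other two entries are both described as non-toxic, the expected step is small, in the direction of a slightly weaker effect at most, and within the usual scatter of the read-out. The estimate for compound 4 in this assay is 10%, with a range from 2% to 25%, which is an expected step of a number 4 percentage points lower from compound 2 to compound 4 (within the scatter) from compound 2.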

Compound 4, a percentage reported as activity, at one concentration (the size of the read-out at that concentration, not a potency): "non-toxic" (no number reported)
The entry for compound 4 holds no number; no gap can be computed for the estimate.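

In this assay compound 2 gives 14% and compound 4 gives "non-toxic" (no number reported) so the step from chloro to hydrogen cannot be read between these two compounds. The compounds shown leave open whether swapping chloro for hydrogen changes the size of the effect at all. No measured evidence bears on this result.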